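Amide substituent changes in a flat solubility series

The source may report more compounds than this note shows. Statements on the series, on what has been measured and on what is new or still open speak of the compounds shown alone.

Measured in a physicochemical assay for solubility, read by spectrophotometry, measured as kinetic solubility, at pH 8, tested at 500 uM; on this read-out lower numbers stand for lower solubility and higher numbers for higher solubility:
- compound 1 `Cn1ccc2ccc(-c3cc(Nc4cnccc4C(=O)NCc4cncnc4)cc4nccnc34)cc21`: 233 ug/mL
- compound 2 `CN1CCC(NC(=O)c2ccncc2Nc2cc(-c3ccc4ccn(C)c4c3)c3nccnc3c2)CC1`: 246 ug/mL
- compound 3 `CC(=O)N1CCCC(NC(=O)c2ccncc2Nc2cc(-c3ccc4ccn(C)c4c3)c3nccnc3c2)C1`: 212 ug/mL

Among the compounds with values here, on the numbers so far, compound 3, at 212 ug/mL, is not separated from the other two. The measured steps read a 1.1-fold lower number from compound 1 to compound 3 (0.04 log units; within the scatter) and a 1.2-fold lower number from compound 2 to compound 3 (0.06 log units; within the scatter). The next structure is compound 4 `CC(=O)N1CCOC(CNC(=O)c2ccncc2Nc2cc(-c3ccc4ccn(C)c4c3)c3nccnc3c2)C1`, which differs as follows: (4-acetylmorpholin-2-yl)methyl in place of 1-acetylpiperidin-3-yl on an amide-type nitrogen. All three measured steps change the group at this same place, on an amide-type nitrogen, and the remaining one reads a 1.1-fold higher number from compound 1 to compound 2 (0.02 log units; within the scatter). None of them lies beyond the scatter, although three different groups are compared. Within the data shown here, no measured compound carries (4-acetylmorpholin-2-yl)methyl, so the evidence for this group is indirect. No step beyond the scatter is therefore expected in this assay, and no direction is favoured. The expected step is a 1.1-fold higher number from compound 3 to compound 4 (0.03 log units; within the scatter). For compound 4 the estimate is 225 ug/mL, with an expected range of 150 ug/mL to 280 ug/mL.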

Compound 4, solubility: 268 ug/mL
Beside the measured number, compound 4's estimate is 1.2-fold (0.08 log units) below it; the range from low to high includes it.
By their numbers in this assay, from the lowest: compounds 3, 1, 2 and 4 (each within the scatter of the next).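

In this assay a fourth group on the amide-type nitrogen, (4-acetylmorpholin-2-yl)methyl, still leaves the number unseparated from the others, with a 1.3-fold higher number from compound 3 to compound 4 (0.10 log units; within the scatter) and a 1.1-fold higher number from compound 2 to compound 4 (0.04 log units; within the scatter) and also a 1.2-fold higher number from compound 1 to compound 4 (0.06 log units; within the scatter) as its steps. The flat reading at this place therefore extends to a group with a second ring hetero atom and 2 hydrogen-bond acceptors, although the step from compound 3 changes the ring and adds the methyl link together, so those two changes cannot be told apart. No measured evidence on the cause of these numbers is available.

Open, going by these compounds, is whether a carboxylic acid or an open-chain primary amine on this nitrogen would give a step beyond the scatter in this assay. Also open, on these data alone, is whether a change on the shared core, away from this amide-type nitrogen, would do so.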